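Chloro for bromo: the step from compound 3 to compound 4

This account rests on a few compounds, and the source may have more. Where it says the series, first, only, none or still open, it means among the compounds named here.

Compound 3 `CN(C)c1ccc(C2CC(c3ccccc3)=NN2C2=NC(=O)/C(=C3\C(=O)Nc4ccc(Br)cc43)S2)cc1` gives 220 nM in a functional assay on cells (Cancer cell lines, Homo sapiens) for cytotoxicity, read by sulforhodamine B assay, with a stated time of 48 h; on this read-out lower numbers stand for stronger inhibition of growth and higher numbers for weaker inhibition of growth. Compound 1 `O=C1N=C(N2N=C(c3ccccc3)CC2c2ccccc2O)S/C1=C1/C(=O)Nc2ccc(Br)cc21` gives 260 nM, and the step of a 1.2-fold lower number from compound 1 to compound 3 (0.07 log units; within the scatter) stays within the scatter, so the two cannot be ordered. Within the data shown here, compound 2 `CN(C)c1ccc(C2CC(c3ccccc3)=NN2C2=NC(=O)/C(=C3\C(=O)Nc4ccccc43)S2)cc1` gives 5260 nM, and a 24-fold lower number from compound 2 to compound 3 (1.38 log units; beyond the scatter) is the one large step in the set. Compound 4 `CN(C)c1ccc(C2CC(c3ccccc3)=NN2C2=NC(=O)/C(=C3\C(=O)Nc4ccc(Cl)cc43)S2)cc1` differs from compound 3 by chloro in place of bromo on an aromatic carbon. Among the measured compounds shown here, only the step from compound 2 to compound 3 touches this position: it shows that a halogen there matters greatly, but says nothing about exchanging one halogen for another. Compound 4 keeps a halogen at that place, so the expected step of a 1.5-fold higher number from compound 3 to compound 4 (0.16 log units; within the scatter) is not beyond the scatter, leaning if anything toward a higher number. The estimate for compound 4 in this assay is 320 nM, ranging from 130 nM to 800 nM.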

Compound 4, concentration for 50% growth inhibition: 220 nM
Compound 4: the middle estimate sits 1.5-fold (0.16 log units) above what was measured, within the range that was stated.
By their numbers in this assay, from the lowest: compounds 3, 4 and 1 (each within the scatter of the next); then compound 2.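

In this assay the exchange of halogen at this aromatic carbon gives no change at the digits printed from compound 3 to compound 4 (within the scatter) and so chloro and bromo cannot be told apart here. Set against hydrogen at the same carbon, chloro gives a 24-fold lower number from compound 2 to compound 4 (1.38 log units; beyond the scatter) and this is the same size as a 24-fold lower number from compound 2 to compound 3 (1.38 log units; beyond the scatter) so the large step is not confined to bromo. Nothing at hand accounts for this result.

Still open, on these data alone, is whether fluoro, methoxy or an amine at this carbon would stay level with the two halogens. Also open, as far as these compounds go, is whether chloro matches bromo when 2-hydroxyphenyl, as in compound 1, replaces 4-(dimethylamino)phenyl.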